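This account rests on a few compounds, and the source may have more. Where it says the series, first, only, none or still open, it means among the compounds named here.

Compounds measured so far:

- compound 1, `COC(=O)[C@@]1(C)CCC=C2[C@@H]1CC[C@@H](C)[C@]2(C)Cc1c[nH]c2ccccc12`: in a functional assay on A549 cells (Homo sapiens) for inhibition, read by sulforhodamine B assay, with a stated time of 48 h (a lower number here means a stronger inhibitor of growth, a higher number a weaker inhibitor of growth), compound 1 gives 5000 nM
- compound 2, `COC(=O)[C@@]1(C)CC[C@@H]2C3=C1CC[C@@H](C)[C@]3(C)C[C@@H]1c3ccccc3N[C@H]21`: in this assay compound 2 gives 39000 nM
- compound 3, `COC(=O)[C@@]1(C)CC[C@@H]2C3=C1CC[C@@H](C)[C@]3(C)C[C@@H]1c3cc(C)ccc3N[C@H]21`: in this assay compound 3 gives 27000 nM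

Compound 3 sits second highest of the three numbers in this assay. Its nearest neighbour is compound 2, the step of a 1.4-fold lower number from compound 2 to compound 3 (0.16 log units; within the scatter) lying within the scatter. For the measured compounds named here, compound 1 stands furthest off, with a lower number beyond the scatter; no single-point step connects compound 1 with compound 3, so only the two values themselves can be set side by side.

Compound 4, `COC(=O)[C@@]1(C)CC[C@@H]2C3=C1CC[C@@H](C)[C@]3(C)C[C@@H]1c3cc(Br)ccc3N[C@H]21`, differs from compound 3 by bromo in place of methyl on an aromatic carbon. Going by the values given here, the one measured step at this position, a 1.4-fold lower number from compound 2 to compound 3 (0.16 log units; within the scatter), put methyl in for hydrogen and stayed within the scatter. Among the compounds with values here, no measured pair shows bromo against methyl, or bromo against hydrogen, anywhere. Within the data shown here, with the only step at this position within the scatter, the expected step of a 1.1-fold lower number from compound 3 to compound 4 (0.03 log units; within the scatter) in this assay is none beyond the scatter, in no settled direction. The estimate for compound 4 in this assay is therefore 25000 nM, with a range from 9000 nM to 70000 nM.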

Compound 4, concentration for 50% growth inhibition: 40000 nM
Compound 4: middle estimate off by 1.6-fold (0.20 log units), on the low side; the range from low to high includes it.
By their numbers in this assay, from the lowest: compound 1; then compounds 3, 2 and 4 (each within the scatter of the next).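

At this aromatic carbon, in this assay, bromo in place of methyl gives a 1.5-fold higher number from compound 3 to compound 4 (0.17 log units; within the scatter), and bromo in place of hydrogen gives a 1.0-fold higher number from compound 2 to compound 4 (0.01 log units; within the scatter). The earlier compounds shown here set only methyl against hydrogen; with bromo added, all three pairings at this carbon lie within the scatter, so none of these groups can be told apart here in this assay, and a single heavy-atom swap of this kind does not separate the compounds. Nothing at hand bears on why this position reads so flat. On these data alone, whether an amine, a carboxylic acid or a longer chain at this carbon would give a step beyond the scatter remains open. So does whether any group on the other carbons of this aromatic ring would move the number at all.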